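Dropping One Trifluoromethyl from a Diaryl Urea

The source may report more compounds than this note shows. Statements on the series, on what has been measured and on what is new or still open speak of the compounds shown alone.

Compound 3 `COc1cc(Cl)cc(-c2nn(-c3cccc(NC(=O)Nc4cc(C(F)(F)F)cc(C(F)(F)F)c4)c3)cc2-c2ccncc2)c1` carries two trifluoromethyl groups on the outer ring of its urea. In a functional assay on SF-268 cells (Homo sapiens) for inhibition, read by sulforhodamine B assay, with a stated time of 48 h, tested at 0.1 uM (on this read-out higher numbers stand for a weaker effect at the one concentration tested and lower numbers for a stronger effect), compound 3 gives 99%. Two close relatives were measured alongside it. Compound 1 `O=C(Nc1cccc(-n2cc(-c3ccncc3)c(-c3cc(O)cc(Cl)c3)n2)c1)Nc1ccc(Cl)c(Cl)c1`, whose urea ends in a ring bearing two chlorines, gives 98%. Compound 2 `COc1cc(Cl)cc(-c2nn(-c3cccc(NC(=O)Nc4ccc(Cl)c(C(F)(F)F)c4)c3)cc2-c2ccncc2)c1`, with one chlorine and one trifluoromethyl on that ring, gives 90%. Compound 3 stands at the highest of the three numbers, but compound 1 lies within the scatter of it, and so does compound 2; all three values describe the same picture, a weak effect at the one concentration tested.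

Compound 4 `COc1cc(Cl)cc(-c2nn(-c3cccc(NC(=O)Nc4cccc(C(F)(F)F)c4)c3)cc2-c2ccncc2)c1` has not yet been measured. Within the data shown here, it differs from compound 3 in one place: hydrogen in place of trifluoromethyl on an aromatic carbon None of the measured pairs shows a step of exactly this kind, so the expectation rests on the spread of the three values, which sit close together. The step from compound 3 to compound 4 is expected to be a number 3 percentage points lower from compound 3 to compound 4 (within the scatter), a change no larger than the scatter. Compound 4 is therefore expected to give about 96% in this assay, within a range from 86% to 103%.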

Compound 4, a percentage reported as activity, at one concentration (the size of the read-out at that concentration, not a potency): 94%
Compound 4: middle estimate off by 2 percentage points, on the high side; measured number inside the range.
By their numbers in this assay, from the lowest: compounds 2, 4, 1 and 3 (each within the scatter of the next).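

In this assay, taking away one trifluoromethyl and leaving hydrogen in its place gives a number 5 percentage points lower from compound 3 to compound 4 (within the scatter), so at this position on the aromatic ring the read-out does not separate trifluoromethyl from hydrogen. The same holds for a second place on that ring, where hydrogen in place of chloro gives a number 4 percentage points higher from compound 2 to compound 4 (within the scatter), so the two single changes, each now read directly between a pair of compounds, both stay inside the usual scatter, which the spread of the earlier values could only suggest. No measurement here offers any explanation of what these groups do or do not contribute to the effect on the cells.

Whether an amine or a carboxylic acid at this position would move the number beyond the scatter remains open, since the compounds shown cover only hydrogen, chloro and trifluoromethyl on this ring. Going by these compounds, all four compounds were read at one low concentration, where the effect is weak, so a difference between them that would appear at higher concentrations also remains unknown.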